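This account rests on a few compounds, and the source may have more. Where it says the series, first, only, none or still open, it means among the compounds named here.

Measured in a physicochemical assay for solubility, using the shake flask method, in simulated intestinal fluid, measured as kinetic solubility, with a stated time of 2 h, at 25 degrees C, at pH 6.5; a higher number here means a more soluble compound, a lower number a less soluble compound:
- compound 1 `CCOC(=O)c1nc(C)c2c(c1N)C(=O)N(Cc1ccccc1)C2=O`: < 5000 nM, a limit
- compound 2 `Cc1nc(C(=O)O)c(N)c2c1C(=O)N(Cc1ccccc1)C2=O`: 177000 nM
- compound 3 `CCCOC(=O)c1nc(C)c2c(c1N)C(=O)N(Cc1ccccc1)C2=O`: < 5000 nM, a limit

Compound 3 stands only at a limit, < 5000 nM. Its position is shared with one other compound, as the limit of < 5000 nM in this assay, at which 2 of the 3 values shown sit, records. Compound 4 `CNC(=O)c1nc(C)c2c(c1N)C(=O)N(Cc1ccccc1)C2=O` has methylamino in place of propoxy on a carbonyl carbon. Two large steps beyond the scatter bear on this change: an at least 35-fold higher number from compound 1 to compound 2 (1.54 log units; beyond the scatter) and an at least 35-fold lower number from compound 2 to compound 3 (1.54 log units; beyond the scatter). Going by the values given here, both turn on a hydrogen on that oxygen, which compound 4 lacks, and no methylamino compound has been measured. A modest rise in this assay is therefore expected, far smaller than either step. The estimated step is an at least 1.2-fold higher number from compound 3 to compound 4 (0.07 log units; that floor lies within the scatter). The estimate for compound 4 is 6000 nM, with an expected range of 2000 nM to 25000 nM.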

Compound 4, solubility: 41000 nM
Beside the measured number, compound 4's estimate is 6.8-fold (0.83 log units) below it; the whole stated range lies below it.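

In this assay, this carbonyl carbon need not carry hydroxy for a compound to clear the limit, with methylamino giving an at least 8.2-fold higher number from compound 3 to compound 4 (0.91 log units; beyond the scatter) and an at least 8.2-fold higher number from compound 1 to compound 4 (0.91 log units; beyond the scatter). Methylamino still falls short of hydroxy, with a 4.3-fold lower number from compound 2 to compound 4 (0.64 log units; beyond the scatter). Compound 1 and compound 3 both stand at a limit, and the steps from them are floors: the limit of < 5000 nM in this assay, at which 2 of the 4 values shown sit.

On these data alone, it remains open whether the rise follows the hydrogen on the methylamino nitrogen or the shorter chain. Dimethylamino or propylamino on this carbonyl carbon would separate the two.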